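A few compounds are considered here, and "the series" means these few. Any claim that something is new, unique, unknown or untested is made for them only; others in the source may bear on it.

Measured compounds in a functional assay on HEK293 cells for agonist activity at Bombesin receptor subtype-3 (Mus musculus), read by luminescence and calcium flux, with a stated time of 10 min; on this read-out lower numbers stand for an effect already at smaller amounts and higher numbers for an effect only at larger amounts of compound:

Compound 1 `CCC(C)(C)Cc1c[nH]c(CCc2ccc(-n3cccn3)cc2)n1` gives 9 nM.
Compound 2 `CCC(C)(C)Cc1c[nH]c(CCc2ccc(-n3ccnn3)cc2)n1` gives 57 nM.
Compound 3 `CCC(C)(C)Cc1c[nH]c(CCc2ccc(-c3cnccn3)cc2)n1` gives 11 nM.

Compound 3 holds the second highest of the three numbers in this assay. Its nearest neighbour is compound 1, a gap that stays within the scatter (a 1.2-fold higher number from compound 1 to compound 3 (0.09 log units; within the scatter)), while its furthest is compound 2 (a 5.2-fold lower number from compound 2 to compound 3 (0.71 log units; beyond the scatter)). The one step that lies beyond the scatter among these three is a 6.3-fold higher number from compound 1 to compound 2 (0.80 log units; beyond the scatter), which separates the two five-membered groups from each other.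

Compound 4 `CCC(C)(C)Cc1c[nH]c(CCc2ccc(-c3cccc(C#N)n3)cc2)n1` has not yet been measured in this assay. It differs from compound 3 in one place: 6-cyanopyridin-2-yl in place of pyrazin-2-yl on an aromatic carbon. Among the compounds with values here, of the measured steps, the closest in kind is the swap of one six-membered group for a five-membered one between compound 1 and compound 3, which stayed within the scatter; no measured step tests the entry of a triple bond outside the aromatic rings. On that basis only a small shift is expected, if any, with the wider margin allowed on the weaker side because compound 2 shows that a change at this position can matter (a 5.2-fold lower number from compound 2 to compound 3 (0.71 log units; beyond the scatter)). The step from compound 3 to compound 4 is therefore estimated at a 1.8-fold higher number from compound 3 to compound 4 (0.26 log units; within the scatter). Compound 4 is expected to give 20 nM in this assay, within a range of 5 nM to 80 nM.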

Compound 4, half-maximal effective concentration: 26 nM
Beside the measured number, compound 4's estimate is 1.3-fold (0.11 log units) below it, and the stated range covers the measured number.
By their numbers in this assay, from the lowest: compounds 1 and 3 (each within the scatter of the next); then compound 4; then compound 2.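

In this assay, the group on this aromatic carbon, para to a large group, can be six-membered and still move the number: the change to 6-cyanopyridin-2-yl brings a 2.4-fold higher number from compound 3 to compound 4 (0.37 log units; beyond the scatter) and so goes beyond the scatter, which the earlier swap from 1H-pyrazol-1-yl to pyrazin-2-yl did not. Compound 4 is also set apart from the pyrazole-bearing compound, with a 2.9-fold higher number from compound 1 to compound 4 (0.46 log units; beyond the scatter) as the step, and from the triazole-bearing one, with a 2.2-fold lower number from compound 2 to compound 4 (0.34 log units; beyond the scatter) as the step, so it takes a level of its own between them. The two six-membered groups therefore do not share one level, just as the two five-membered groups do not, and ring size alone does not sort these four compounds.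

Because 6-cyanopyridin-2-yl differs from pyrazin-2-yl in both the ring and the added nitrile, the compounds shown cannot separate the two changes; plain pyridin-2-yl would be needed for that, and how a carboxylic acid or an aminomethyl group in place of the nitrile would read also remains open. Nothing at hand gives a reason for any of these steps.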